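A few compounds are considered here, and "the series" means these few. Any claim that something is new, unique, unknown or untested is made for them only; others in the source may bear on it.

Working notes on the series. Three measured compounds share one core and differ only in the group on an amine nitrogen. In a functional assay on MCF7 cells (Homo sapiens) for cytotoxicity, read by MTT assay, with a stated time of 48 h (on this read-out lower numbers stand for stronger inhibition and higher numbers for weaker inhibition), compound 1 `Cc1ccc(S(=O)(=O)/N=C(/CCNC2=CC(=O)c3ccccc3C2=O)Nc2cccc(C)c2)cc1` gives 8120 nM. In this assay compound 2 `COc1ccc(N/C(CCNC2=CC(=O)c3ccccc3C2=O)=N\S(=O)(=O)c2ccc(C)cc2)c(OC)c1` gives 30200 nM. In this assay compound 3 `COc1cc(N/C(CCNC2=CC(=O)c3ccccc3C2=O)=N\S(=O)(=O)c2ccc(C)cc2)cc(OC)c1OC` gives 3050 nM, the lowest of the three numbers: a 2.7-fold lower number from compound 1 to compound 3 (0.43 log units; beyond the scatter) and a 9.9-fold lower number from compound 2 to compound 3 (1.00 log units; beyond the scatter), both beyond the scatter, while a 3.7-fold higher number from compound 1 to compound 2 (0.57 log units; beyond the scatter).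

Compound 4 `Cc1ccc(S(=O)(=O)/N=C(/CCNC2=CC(=O)c3ccccc3C2=O)NC2CCCCC2)cc1` carries the change (cyclohexyl in place of 3,4,5-trimethoxyphenyl on an amine nitrogen). For the measured compounds named here, no measured step replaces the six-membered aromatic ring by a six-membered non-aromatic ring, so there is no direct precedent. Going by the values given here, the steps that bear on it are a 2.7-fold lower number from compound 1 to compound 3 (0.43 log units; beyond the scatter) and a 9.9-fold lower number from compound 2 to compound 3 (1.00 log units; beyond the scatter), which show that the 3,4,5-trimethoxyphenyl of compound 3 goes with the lowest number and that the other groups on this nitrogen give higher numbers. Losing that group is therefore expected to raise the number in this assay, with a step of moderate size and wide uncertainty. For compound 4 the expected step is a 3.0-fold higher number from compound 3 to compound 4 (0.47 log units; beyond the scatter). Compound 4 is estimated at 9000 nM, within a range of 3000 nM to 35000 nM.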

Compound 4, half-maximal inhibitory concentration: 7580 nM
Estimate against measurement, compound 4: 1.2-fold (0.07 log units) above; the range from low to high includes it.
By their numbers in this assay, from the lowest: compound 3; then compounds 4 and 1 (each within the scatter of the next); then compound 2.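

In this assay the cyclohexyl on this amine nitrogen gives a number inside the span set by the aromatic groups (a 2.5-fold higher number from compound 3 to compound 4 (0.40 log units; beyond the scatter); a 4.0-fold lower number from compound 2 to compound 4 (0.60 log units; beyond the scatter)), so within these compounds a six-membered aromatic ring at this position is not needed to reach that span. The comparison with 3-methylphenyl (a 1.1-fold lower number from compound 1 to compound 4 (0.03 log units; within the scatter)) does not separate the non-aromatic ring from the aromatic one, and the change from aromatic to non-aromatic therefore has no single direction here: the outcome depends on which aromatic group it replaces. Nothing at hand accounts for these differences.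

The compounds shown leave open how a five-membered or seven-membered non-aromatic ring or an open butyl chain would read on this nitrogen. They also leave open whether methoxy groups on the cyclohexyl ring would give a number like that of compound 3.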